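Butyl in place of chloropyridinylmethyl on the ring amide nitrogen

The compounds below may be only part of what the source reports. "The series", "measured", "known", "first", "only" and "open" are said of these compounds alone.

compound 1 `CCCCN1CCn2nc(-c3ccccc3)cc2C1=O` > 64000 nM
compound 2 `O=C1c2cc(-c3ccc(Cl)cc3)nn2CCN1Cc1ccc(Cl)nc1` 39500 nM

In a functional assay on A549 cells (Homo sapiens) for inhibition, read by MTT assay, with a stated time of 48 h (a lower number here means a stronger inhibitor, a higher number a weaker inhibitor), compound 1 gives > 64000 nM, a limit of the assay rather than a number. Compound 2 gives 39500 nM in this assay and is the only number shown. The other value, that of compound 1, is a limit (the limit of > 64000 nM in this assay, at which 1 of the 2 values shown sits). Compound 3 `CCCCN1CCn2nc(-c3ccc(Cl)cc3)cc2C1=O` awaits measurement. It differs from compound 2 by propyl in place of 6-chloropyridin-3-yl on a saturated chain carbon bound to an amide-type nitrogen in a ring. No measured step sizes this change. The step of a 1.4-fold higher number from compound 2 to compound 3 (0.14 log units; within the scatter) is expected to be modest, toward weaker inhibition. Compound 3 is estimated at 55000 nM, within 25000 nM to 130000 nM, with a fair chance of only a limit.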

Compound 3, half-maximal inhibitory concentration: 29800 nM
Compound 3: middle estimate off by 1.8-fold (0.27 log units), on the high side, within the range that was stated.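

Propyl in place of 6-chloropyridin-3-yl at this place gives a 1.3-fold lower number from compound 2 to compound 3 (0.12 log units; within the scatter), so in this assay the aromatic ring of that group is not required for the activity seen in this pair. Among these compounds, with butyl held fixed, chloro in place of hydrogen on an aromatic carbon gives an at least 2.1-fold lower number from compound 1 to compound 3 (0.33 log units; beyond the scatter), the first step beyond the scatter. Compound 1 stands only as a limit, not a number: the limit of > 64000 nM in this assay, at which 1 of the 3 values shown sits.

Going by these compounds, whether an amine, a carboxylic acid or a longer chain at this place would move the value stays open. So does whether a group other than chloro on that aromatic carbon would give a step of similar size.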